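This account rests on a few compounds, and the source may have more. Where it says the series, first, only, none or still open, it means among the compounds named here.

Compound 1 `CS/C(=N\C(=O)c1cc2ccccc2s1)NC(=O)c1cc2ccccc2s1`, which in a functional assay on MCF7 cells (Homo sapiens) for cytotoxicity, read by MTT assay, with a stated time of 72 h (a higher number here means a weaker inhibitor of growth, a lower number a stronger inhibitor of growth), gives 43400 nM.
Compound 2 `O=C(/N=C(/NC(=O)c1cc(-c2ccccc2)nc2ccccc12)[Se]Cc1ccccc1)c1cc(-c2ccccc2)nc2ccccc12`, which in this assay gives 45600 nM.

Compound 2 has the higher of the two numbers, but its gap to compound 1 lies within the scatter, so no order between them can be read. Compound 3 `C[Se]/C(=N\C(=O)c1cc(-c2ccccc2)nc2ccccc12)NC(=O)c1cc(-c2ccccc2)nc2ccccc12` differs from compound 2 by hydrogen in place of phenyl on a saturated chain carbon bound to a selenium atom. Going by the values given here, no measured pair shows this change, and compound 1, built on another core, sits close to compound 2. The step from compound 2 to compound 3 is therefore expected to stay within the scatter, about a 1.1-fold lower number from compound 2 to compound 3 (0.04 log units; within the scatter). Compound 3 is estimated at 42000 nM, in a range from 15000 nM to 120000 nM.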

Compound 3, concentration for total growth inhibition: 7520 nM
The estimate for compound 3 lay 5.6-fold (0.75 log units) above the measured number; measured number outside the range, below it.
By their numbers in this assay, from the lowest: compound 3; then compounds 1 and 2 (each within the scatter of the next).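

Moving from benzyl to methyl on the selenium atom matters in this assay: the change gives a 6.1-fold lower number from compound 2 to compound 3 (0.78 log units; beyond the scatter), so this position can shift growth inhibition by more than the scatter, and here the shorter group goes with the stronger result. This single pair cannot say why, and nothing measured here accounts for the step.

As far as these compounds go, it remains open how an ethyl group, a longer chain or a chain ending in an amine would read at this position. From the compounds shown here alone, whether the same change would act alike on the core of compound 1 is also open.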